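This account rests on a few compounds, and the source may have more. Where it says the series, first, only, none or still open, it means among the compounds named here.

Compound 2 `CCCCSc1nc(N)c2nc(O)n(Cc3ccccc3)c2n1` gives 0.3 mg/kg in a functional assay on the whole organism for activation, with Mus musculus as the target (on this read-out lower numbers stand for an effect already at smaller amounts and higher numbers for an effect only at larger amounts of compound), the higher of the two numbers measured; the other belongs to compound 1 `CCSc1nc(N)c2nc(O)n(Cc3ccccc3)c2n1`, which in this assay gives 0.1 mg/kg. For the measured compounds named here, the one measured step, a 3.0-fold higher number from compound 1 to compound 2 (0.48 log units; beyond the scatter), lengthened the chain on sulfur. Compound 3 `CCCc1nc(N)c2nc(O)n(Cc3ccccc3)c2n1` differs from compound 2 by propyl in place of butylsulfanyl on an aromatic carbon. Going by the values given here, no measured step covers this exchange, so the step from compound 2 to compound 3 in this assay is expected to stay close to the scatter, estimated as a 1.5-fold lower number from compound 2 to compound 3 (0.18 log units; within the scatter). Compound 3 is therefore expected to give about 0.2 mg/kg, between 0.05 mg/kg and 0.8 mg/kg.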

Compound 3, minimum effective dose: 3 mg/kg
Compound 3: the middle estimate sits 15-fold (1.18 log units) below what was measured; measured number above the stated range.
By their numbers in this assay, from the lowest: compound 1; then compound 2; then compound 3.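

In this assay, exchanging the sulfur-linked chain on this aromatic carbon for propyl gives a 10-fold higher number from compound 2 to compound 3 (1.00 log units; beyond the scatter) and, starting from the ethylsulfanyl group, a 30-fold higher number from compound 1 to compound 3 (1.48 log units; beyond the scatter). Among these three compounds, both sulfur-linked chains therefore give lower numbers than propyl, and this position responds to the exchange more than to the lengthening on sulfur. No evidence on the cause is available.

From the compounds shown here alone, the exchange alters the sulfur and the chain together, so their separate shares remain open. A pentyl chain, a butoxy group or an amine on this carbon would bear on that question.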